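Moving the Chlorine on the Benzyloxy Group of Compound 3

The source may hold more compounds than are shown below. What is called first, only, known or untested is meant among the compounds shown, and "the series" means these compounds.

Within the data shown here, compound 3 `FC(F)(F)c1ccc(CN2CCN(Cc3cc(-c4ccc(OCc5ccccc5Cl)cc4)on3)CC2)cc1` gives 2800 nM in a functional assay on MCF7 cells (Homo sapiens) for antiproliferative activity, read by sulforhodamine B assay, with a stated time of 72 h (a higher number here means a weaker inhibitor, a lower number a stronger inhibitor), the second highest of the three numbers known. Its companions are compound 1 `Cc1ccccc1COc1ccc(-c2cc(CN3CCN(Cc4ccc(C(F)(F)F)cc4)CC3)no2)cc1` at 3700 nM and compound 2 `Cc1cc(C)cc(COc2ccc(-c3cc(CN4CCN(Cc5ccc(C(F)(F)F)cc5)CC4)no3)cc2)c1` at 1600 nM; the step of a 1.3-fold lower number from compound 1 to compound 3 (0.12 log units; within the scatter) and the step of a 1.8-fold higher number from compound 2 to compound 3 (0.24 log units; within the scatter) both stay within the scatter. Compound 4 `FC(F)(F)c1ccc(CN2CCN(Cc3cc(-c4ccc(OCc5ccc(Cl)cc5)cc4)on3)CC2)cc1` differs from compound 3 by 4-chlorophenyl in place of 2-chlorophenyl on a saturated chain carbon bound to an oxygen on an aromatic ring. Among the measured compounds shown here, the only change so far that reached beyond the scatter is a 2.3-fold lower number from compound 1 to compound 2 (0.36 log units; beyond the scatter), in which the substitution of the benzyloxy ring was altered, whereas the exchange of methyl for chloro gave only a 1.3-fold lower number from compound 1 to compound 3 (0.12 log units; within the scatter). Relocating the chlorine within that ring is therefore expected to give a small step, a 1.4-fold lower number from compound 3 to compound 4 (0.15 log units; within the scatter), toward a lower number. Compound 4 is estimated at 2000 nM, within a range from 900 nM to 4500 nM.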

Compound 4, half-maximal inhibitory concentration: 6700 nM
Beside the measured number, compound 4's estimate is 3.4-fold (0.53 log units) below it; measured number above the stated range.
By their numbers in this assay, from the lowest: compounds 2, 3, 1 and 4 (each within the scatter of the next, the first and the last beyond it).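

In this assay, 4-chlorophenyl in place of 2-chlorophenyl gives a 2.4-fold higher number from compound 3 to compound 4 (0.38 log units; beyond the scatter), so with the same atoms joined differently, the place of the chlorine on this ring alone moves the number beyond the scatter. The gap widens to a 4.2-fold higher number from compound 2 to compound 4 (0.62 log units; beyond the scatter), whereas a 1.8-fold higher number from compound 1 to compound 4 (0.26 log units; within the scatter) leaves 4-chlorophenyl and 2-methylphenyl indistinguishable here. Nothing available gives a reason for the effect of moving the chlorine. The compounds shown leave open whether a fluoro or a methoxy group on this ring would show the same dependence on place.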